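Notes on the aryl substituent series: step to compound 4

The source may report more compounds than this note shows. Statements on the series, on what has been measured and on what is new or still open speak of the compounds shown alone.

Compound 3 `CCCS(=O)(=O)Nc1ccc(F)c(C(=O)c2n[nH]c3ncc(-c4ccc([N+](=O)[O-])cc4)cc23)c1F` gives 4.2% in an assay for binding affinity to dual specificity mitogen-activated protein kinase kinase 4 (Homo sapiens), read by KINOMEscan, tested at 100 nM; a lower number here means a stronger effect, a higher number a weaker effect of the compound at the concentration tested. Compound 2 `CCCS(=O)(=O)Nc1ccc(F)c(C(=O)c2n[nH]c3ncc(-c4cccc(OC)c4)cc23)c1F` gives 6.3%, and the step of a number 2.1 percentage points lower from compound 2 to compound 3 (within the scatter) is within the scatter, so the two stand in one band. Compound 1 `CCCS(=O)(=O)Nc1ccc(F)c(C(=O)c2n[nH]c3ncc(-c4cccc(Cl)c4)cc23)c1F` gives 40%; the steps of a number 33.7 percentage points lower from compound 1 to compound 2 (beyond the scatter) and a number 35.8 percentage points lower from compound 1 to compound 3 (beyond the scatter) are both large. Compound 3 therefore sits at the low end of the three numbers, not separated from compound 2.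

Compound 4 `CCCS(=O)(=O)Nc1ccc(F)c(C(=O)c2n[nH]c3ncc(-c4ccc(S(=O)(=O)NCC)cc4)cc23)c1F` differs from compound 3 as ethylsulfamoyl in place of nitro on an aromatic carbon. Within the data shown here, no measured step swaps one group for another at this place on the ring, so the steps that bear on it are only a number 35.8 percentage points lower from compound 1 to compound 3 (beyond the scatter) and a number 2.1 percentage points lower from compound 2 to compound 3 (within the scatter), which put the 4-nitrophenyl compound well below the 3-chlorophenyl compound and level with the 3-methoxyphenyl compound. Going by these compounds, whether the ethylsulfamoyl group holds that level is untested. Compound 4 is expected to remain toward the low band, with a step of a number 7.8 percentage points higher from compound 3 to compound 4 (within the scatter) that could reach beyond the scatter in the weaker direction. The estimate for compound 4 is 12%, range 3% to 38%.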

Compound 4, a percentage reported as activity, at one concentration (the size of the read-out at that concentration, not a potency): 3%
For compound 4 the middle estimate is 9 percentage points above the measured one, and the stated range covers the measured number.
By their numbers in this assay, from the lowest: compounds 4, 3 and 2 (each within the scatter of the next); then compound 1.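

In this assay, ethylsulfamoyl in place of nitro gives a step that stays level (a number 1.2 percentage points lower from compound 3 to compound 4 (within the scatter)), so a larger group carrying a hydrogen-bond donor can stand para to a large group without leaving the low band. The 4-(ethylsulfamoyl)phenyl group also stands level with the 3-methoxyphenyl group (a number 3.3 percentage points lower from compound 2 to compound 4 (within the scatter)) and well apart from the 3-chlorophenyl group (a number 37 percentage points lower from compound 1 to compound 4 (beyond the scatter)), so three of the four aryl groups now share the low band and only compound 1 lies outside it. Nothing available here accounts for this tolerance.

Going by these compounds, whether the number of compound 1 follows from the chloro group itself or from where it sits on the ring stays open. Also open, on these data alone, is whether a carboxylic acid or an amine at this place, or a longer chain on the sulfamoyl nitrogen, would stay in the low band.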